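Trimming a Methyl from the Piperidine Amide

A few compounds are considered here, and "the series" means these few. Any claim that something is new, unique, unknown or untested is made for them only; others in the source may bear on it.

Of the compounds shown here, two sharing one core have been measured in an assay on isolated protein for inhibition of thyroid hormone receptor beta (Homo sapiens), read by fluorescence, with a stated time of 30 min; a higher number here means a weaker inhibitor, a lower number a stronger inhibitor. Compound 1 `CCCN(CC1CCOC1)C(=O)c1cc(OC)c2oc(NCc3cccc(Cl)c3)nc2c1` gives 12 nM in this assay. Compound 2 `COc1cc(C(=O)N2CC[C@@H](O)C(C)(C)C2)cc2nc(NCc3cccc(Cl)c3)oc12`, which carries a different amide substituent, gives 35 nM. Going by the values given here, the only step between measured compounds, a 2.9-fold higher number from compound 1 to compound 2 (0.46 log units; beyond the scatter), so compound 2 stands with the higher of the two numbers, and compound 1 is the nearest point of comparison.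

Compound 3 `COc1cc(C(=O)N2CC[C@@H](O)[C@H](C)C2)cc2nc(NCc3cccc(Cl)c3)oc12` is not yet measured. It differs from compound 2 in one place: 4-hydroxy-3-methylpiperidin-1-yl in place of 4-hydroxy-3,3-dimethylpiperidin-1-yl on a carbonyl carbon. This is the loss of a single methyl from the ring, with the hydroxyl and the amide linkage kept.

Among the compounds with values here, no measured step bears directly on this change; the step from compound 1 to compound 2 swaps the whole amide substituent rather than trimming one methyl. Such a small change is expected to move this assay little, if at all beyond the scatter, and in no predictable direction. This amounts to an expected no change at the digits printed from compound 2 to compound 3 (within the scatter). Compound 3 is therefore estimated at 35 nM in this assay, with a plausible range from 12 nM to 100 nM.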

Compound 3, half-maximal inhibitory concentration: 10 nM
Compound 3: middle estimate off by 3.5-fold (0.54 log units), on the high side, and the stated range ends above it.
By their numbers in this assay, from the lowest: compounds 3 and 1 (each within the scatter of the next); then compound 2.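

In this assay, removing one methyl from the ring is enough to shift the result, with a 3.5-fold lower number from compound 2 to compound 3 (0.54 log units; beyond the scatter), so even this small edit to the amide substituent registers beyond the scatter. The comparison with the open-chain amide gives a 1.2-fold lower number from compound 1 to compound 3 (0.08 log units; within the scatter), which places these two quite different substituents level within the scatter; the weaker result of compound 2 is therefore not shared by every 4-hydroxypiperidine amide shown here, and among these compounds it appears only with the 3,3-dimethyl pattern. Nothing available explains why the second methyl carries this penalty.

The compounds shown leave open whether the plain 4-hydroxypiperidin-1-yl group, with no methyl on the ring, would stay level with compound 3 or move away from it, and whether a longer chain such as ethyl could take the place of the remaining methyl. From the compounds shown here alone, compound 3 also shows only one arrangement of its 2 defined stereocentres, so the effect of inverting the methyl-bearing centre remains unknown.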